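The compounds below may be only part of what the source reports. "The series", "measured", "known", "first", "only" and "open" are said of these compounds alone.

Of the compounds shown here, three sharing one core have been measured in an ADME assay (liver) for metabolic stability, with Liver microsome (Rattus norvegicus) as the target, using microsomes and NADPH, with a stated time of 30 min, tested at 1 uM; on this read-out lower numbers stand for slow clearance and higher numbers for fast clearance. Compound 1 `Cn1cc(-c2cc(C(O)(C(F)(F)F)C(F)(F)F)cnc2N2CCN(S(=O)(=O)c3ccc(N)nc3)CC2)cn1` gives 44 mL.min-1.g-1; compound 2 `Nc1ccc(S(=O)(=O)N2CCN(c3ncc(C(O)(C(F)(F)F)C(F)(F)F)cc3-c3ccoc3)CC2)cn1` gives 57 mL.min-1.g-1; compound 3 `NC(=O)c1cccc(-c2cc(C(O)(C(F)(F)F)C(F)(F)F)cnc2N2CCN(S(=O)(=O)c3ccc(N)nc3)CC2)c1` gives 63 mL.min-1.g-1, and all three numbers lie within the scatter of one another, so that a 1.3-fold higher number from compound 1 to compound 2 (0.11 log units; within the scatter), a 1.4-fold higher number from compound 1 to compound 3 (0.16 log units; within the scatter) and a 1.1-fold higher number from compound 2 to compound 3 (0.04 log units; within the scatter) are each too small to count as real steps.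

Compound 4 `Nc1ccc(S(=O)(=O)N2CCN(c3ncc(C(O)(C(F)(F)F)C(F)(F)F)cc3-c3cc4ccccc4s3)CC2)cn1` is the next compound, and the change from compound 3 is 1-benzothiophen-2-yl in place of 3-carbamoylphenyl on an aromatic carbon. The three earlier steps, each a swap of the group at this same position, bear on it and all stayed within the scatter. Compound 4 is therefore expected to show a 1.2-fold higher number from compound 3 to compound 4 (0.08 log units; within the scatter), and its value in this assay is estimated at 75 mL.min-1.g-1, within a range from 40 mL.min-1.g-1 to 140 mL.min-1.g-1.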

Compound 4, intrinsic clearance in microsomes: 315 mL.min-1.g-1
Compound 4: the middle estimate sits 4.2-fold (0.62 log units) below what was measured, outside the stated range (above it).
By their numbers in this assay, from the lowest: compounds 1, 2 and 3 (each within the scatter of the next); then compound 4.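

In this assay this position proves less indifferent than the earlier swaps suggested: 1-benzothiophen-2-yl gives a 5.0-fold higher number from compound 3 to compound 4 (0.70 log units; beyond the scatter) and a 5.5-fold higher number from compound 2 to compound 4 (0.74 log units; beyond the scatter) and also a 7.2-fold higher number from compound 1 to compound 4 (0.85 log units; beyond the scatter) while the three earlier groups stayed within the scatter of one another. Among the four groups it alone has two aromatic rings and alone carries sulfur. Nothing available explains the rise. Going by these compounds, whether the second ring or the sulfur matters stays open. A thiophen-2-yl or a benzofuran-2-yl group at this place would separate the two.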